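This account rests on a few compounds, and the source may have more. Where it says the series, first, only, none or still open, it means among the compounds named here.

Measured so far:
Compound 1 `CCOc1cc(NC(=O)CCCCCNC(=O)CCCc2ccccc2)cc2c1OCC([N+](=O)[O-])=C2` — 7170 nM
Compound 2 `CCOc1cc(NC(=O)CCCCC(=O)Nc2cc(-c3ccccc3)ccc2N)cc2c1OCC([N+](=O)[O-])=C2` — 14600 nM
Compound 3 `CCOc1cc(NC(=O)CCCCCCC(=O)Nc2cc(-c3ccccc3)ccc2N)cc2c1OCC([N+](=O)[O-])=C2` — 10700 nM

The three compounds were tested in a functional assay on PC-3 cells (Homo sapiens) for antiproliferative activity, read by MTT assay, with a stated time of 48 h; on this read-out lower numbers stand for stronger inhibition of growth and higher numbers for weaker inhibition of growth. Compound 1 gives the lowest of the three numbers there. Compound 3 is the nearest to it, and the gap between the two lies within the usual scatter of such measurements, so no order can be drawn between them. Compound 2 is the furthest from compound 1, and that gap is beyond the scatter.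

Compound 4 `CCOc1cc(NC(=O)CCCCCC(=O)Nc2ccccc2N)cc2c1OCC([N+](=O)[O-])=C2` has not yet been measured in this assay. Against compound 1 the change is (2-aminophenyl)carbamoyl in place of ((3-phenylpropyl)carbonyl)amino on a saturated chain carbon, five bonds along the chain from a carbonyl carbon. Among the compounds with values here, no measured pair shows this change directly, so its size must be judged from what the three numbers show. Compounds 2 and 3, whose structures stand beside them, are closer in build to compound 4 than compound 1 is, and both give higher numbers than compound 1 in this assay, though only compound 2 does so beyond the scatter. Compound 4 is therefore expected to come in at a slightly higher number than compound 1, with a step of a 1.3-fold higher number from compound 1 to compound 4 (0.12 log units; within the scatter), though one that may well stay within the scatter. In this assay the value of compound 4 is estimated at 9500 nM, in the range from 3500 nM to 26000 nM.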

Compound 4, concentration for 50% growth inhibition: > 20000 nM
Compound 4 gave a limit, no number (the forecaster's own chance of this, stated with the estimate: 5%); middle value at least 2.1-fold (0.32 log units) away from the limit.
By their numbers in this assay, from the lowest: compounds 1, 3 and 2 (each within the scatter of the next, the first and the last beyond it). At a limit, above all of these: compound 4.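

In this assay, the reading for compound 4 is a limit and not a number: the limit of > 20000 nM in this assay, at which 1 of the 4 values shown sits. On a saturated chain carbon, five bonds along the chain from a carbonyl carbon, putting (2-aminophenyl)carbamoyl in place of ((3-phenylpropyl)carbonyl)amino gives an at least 2.7-fold higher number from compound 1 to compound 4 (0.44 log units; beyond the scatter), the first step seen between measured compounds that differ in one place, and it shows that growth inhibition at this position depends on the group carried there. Both groups hold one six-membered aromatic ring of carbon only, so the presence of such a ring on the chain is not enough by itself to keep the number of compound 1.

As far as these compounds go, how large the step really is remains open, since one end of it is a limit, and this single pair cannot separate the contribution of the amine on the ring from that of the rest of the exchanged group. Also open, from the compounds shown here alone, is how a plain phenylcarbamoyl group, which has no amine on its ring, or a carboxylic acid on the same chain carbon would read in this assay.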